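Swapping a Butyl Chain for a Cyclopropylcarbonyl Group

The compounds below may be only part of what the source reports. "The series", "measured", "known", "first", "only" and "open" are said of these compounds alone.

Compound 1 `Cc1cccc(C#Cc2nc3c(s2)C(=O)NCC3)c1`: > 10000 nM
Compound 2 `CCCCN1CCc2nc(C#Cc3ccccc3)sc2C1`: 110 nM
Compound 3 `Fc1cccc(C#Cc2nc3c(s2)CN(C2CCOC2)CC3)c1`: > 10000 nM

Within the data shown here, in an assay on HEK293 cells for positive allosteric modulation of metabotropic glutamate receptor 5 (Homo sapiens), read by FLIPR, with a stated time of 1 h (on this read-out lower numbers stand for an effect already at smaller amounts and higher numbers for an effect only at larger amounts of compound), compound 2 gives 110 nM, the only actual number among the three. Compound 1 gives > 10000 nM, which is a limit of the assay. Compound 3 likewise gives > 10000 nM, a limit. Two of three values therefore sit at the limit of > 10000 nM in this assay, at which 2 of the 3 values shown sit, so compound 2 is the only anchor for any expectation.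

Compound 4 `O=C(C1CC1)N1CCc2nc(C#Cc3ccccc3)sc2C1` has not been measured. It differs from compound 2 by cyclopropylcarbonyl in place of butyl on an amine nitrogen in a ring. Among the measured compounds shown here, no measured pair shows this kind of change, so the direction is open. A loss somewhat beyond the scatter is expected, shown as the step of a 3.6-fold higher number from compound 2 to compound 4 (0.56 log units; beyond the scatter). Compound 4 is estimated at 400 nM, plausibly between 80 nM and 3000 nM.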

Compound 4, half-maximal effective concentration: > 10000 nM
Compound 4: a limit, no number (the forecaster's own chance of this, stated with the estimate: 25%); middle value at least 25-fold (1.39 log units) away from the limit.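

Among these compounds, this is the only step here that changes a single place, and it shows that the group on the amine nitrogen in a ring matters greatly in this assay: cyclopropylcarbonyl in place of butyl gives an at least 90-fold higher number from compound 2 to compound 4 (1.95 log units; beyond the scatter). The true size of this step stays unknown, since compound 4 gives a limit and not a number: the limit of > 10000 nM in this assay, at which 3 of the 4 values shown sit.

This change brings in a carbonyl and a small ring together, so the compounds shown cannot say which of the two counts. A cyclopropylmethyl group or an acetyl group on the same nitrogen would separate them.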